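Replacing a Carboxymethyl Group by a Pyridinylmethylcarbamoyl Group

This account rests on a few compounds, and the source may have more. Where it says the series, first, only, none or still open, it means among the compounds named here.

Compound 1 `O=C(Nc1ccccc1)c1cn(Cc2c(F)cccc2F)c2ccc(=O)[nH]c2c1=O`: in an in vitro assay on Sf21 cells for inhibition of high affinity 3',5'-cyclic-AMP phosphodiesterase 7A (Homo sapiens), read by scintillation proximity assay, with a stated time of 30 min (on this read-out higher numbers stand for weaker inhibition and lower numbers for stronger inhibition), compound 1 gives 94 nM.
Compound 2 `O=C(O)Cc1ccc(NC(=O)c2cn(Cc3c(F)cccc3F)c3ccc(=O)[nH]c3c2=O)cc1`: in this assay compound 2 gives 176 nM.

The two measured compounds share one core and differ in a single place, carboxymethyl in place of hydrogen on an aromatic carbon. Of the two numbers, compound 2 gives the nominally higher one, yet the step of a 1.9-fold higher number from compound 1 to compound 2 (0.27 log units; within the scatter) lies within the scatter, so the two compounds cannot be told apart on these data.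

Compound 3 `O=C(NCc1ccncc1)c1ccc(NC(=O)c2cn(Cc3c(F)cccc3F)c3ccc(=O)[nH]c3c2=O)cc1` has not yet been measured. It differs from compound 2 in one place: ((pyridin-4-yl)methyl)carbamoyl in place of carboxymethyl on an aromatic carbon. Among the measured compounds shown here, the only measured step that bears on this change is the one at the same aromatic carbon, from compound 1 to compound 2, and that step stayed within the scatter. With nothing else to go on, a step of similar size is expected, in no direction beyond the scatter. Compound 3 is therefore estimated at 150 nM, with a range from 50 nM to 450 nM. The expected step of a 1.2-fold lower number from compound 2 to compound 3 (0.07 log units; within the scatter) is thus within the scatter.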

Compound 3, half-maximal inhibitory concentration: 20 nM
Compound 3: the middle estimate sits 7.5-fold (0.88 log units) above what was measured; measured number below the stated range.
By their numbers in this assay, from the lowest: compound 3; then compounds 1 and 2 (each within the scatter of the next).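

At this aromatic carbon, para to a large group, the number in this assay does respond to the substituent, a point the earlier pair could not establish, as hydrogen and carboxymethyl there could not be told apart. ((pyridin-4-yl)methyl)carbamoyl in place of carboxymethyl gives an 8.8-fold lower number from compound 2 to compound 3 (0.94 log units; beyond the scatter) and in place of hydrogen gives a 4.7-fold lower number from compound 1 to compound 3 (0.67 log units; beyond the scatter) as well, so both steps lie beyond the scatter and compound 3 is the strongest inhibitor of the three. The position therefore accepts a group of this size, and the entering group, with its six-membered aromatic ring holding one hetero atom, goes with stronger inhibition than either group compared with it.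

The compounds shown leave open which part of that group goes with the change: the carbamoyl link, the pyridine ring or its nitrogen. A benzylcarbamoyl group with a ring of carbon only, a plain methylcarbamoyl group, a (pyridin-3-yl)methyl isomer or a simple amine at this carbon would separate these parts. No measurement is available here that explains the step.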